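Changing the benzyl group on a weakly active compound

This account rests on a few compounds, and the source may have more. Where it says the series, first, only, none or still open, it means among the compounds named here.

compound 1 `COc1cc(N(Cc2ccc(C)cc2)C(=O)CSc2nc3ccccc3s2)cc(OC)c1OC`: 54200 nM
compound 2 `COc1ccc(CN(C(=O)CSc2nc3ccccc3s2)c2cc(OC)c(OC)c(OC)c2)cc1[N+](=O)[O-]`: 682 nM
compound 3 `COc1ccc(CN(C(=O)CSc2nc3ccccc3s2)c2cc(OC)c(OC)c(OC)c2)cc1OC`: 34100 nM
compound 4 `COc1cc(N(Cc2ccc(Br)cc2)C(=O)CSc2nc3ccccc3s2)cc(OC)c1OC`: not yet measured

In a functional assay on MGC-803 cells (Homo sapiens) for antiproliferative activity, read by MTT assay, with a stated time of 48 h (on this read-out lower numbers stand for stronger inhibition and higher numbers for weaker inhibition), compound 3 gives 34100 nM. Its nearest neighbour lies within the scatter, a 1.6-fold lower number from compound 1 to compound 3 (0.20 log units; within the scatter), while the remaining value is far away, a 50-fold higher number from compound 2 to compound 3 (1.70 log units; beyond the scatter).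

The next structure has 4-bromophenyl in place of 3,4-dimethoxyphenyl on a saturated chain carbon bound to an amide-type nitrogen.

The measured steps at this same place are the guide. Exchanging the 4-methylphenyl and 3,4-dimethoxyphenyl groups made no change beyond the scatter. Only the group carrying a nitro stands apart, a 79-fold lower number from compound 1 to compound 2 (1.90 log units; beyond the scatter), and the incoming 4-bromophenyl has no nitro. Three compounds cannot establish a rule, so the range must stay wide.

The expected size is a 1.4-fold lower number from compound 3 to compound 4 (0.13 log units; within the scatter), which would not go beyond the scatter. For compound 4 the estimated value in this assay is 25000 nM, with an expected range of 4000 nM to 80000 nM.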

Compound 4, half-maximal inhibitory concentration: 48100 nM
The estimate for compound 4 lay 1.9-fold (0.28 log units) below the measured number; the range from low to high includes it.
By their numbers in this assay, from the lowest: compound 2; then compounds 3, 4 and 1 (each within the scatter of the next).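

In this assay, 4-bromophenyl now joins 4-methylphenyl and 3,4-dimethoxyphenyl as a third group giving no change beyond the scatter (a 1.4-fold higher number from compound 3 to compound 4 (0.15 log units; within the scatter)) and (a 1.1-fold lower number from compound 1 to compound 4 (0.05 log units; within the scatter)). This holds even though bromo is a different kind of atom from the methyl and methoxy groups, so among these benzyl groups only compound 2, the one compound that goes against this flat picture, stands apart (a 71-fold higher number from compound 2 to compound 4 (1.85 log units; beyond the scatter)). Nothing available explains why the 4-methoxy-3-nitrophenyl group stands apart.

From the compounds shown here alone, it remains open whether the nitro gives this gap alone or only together with the methoxy on the same ring. Going by these compounds, it is also open whether a nitrile or an amine in the place of the nitro would give a number like that of compound 2 or like those of the other three.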